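A few compounds are considered here, and "the series" means these few. Any claim that something is new, unique, unknown or untested is made for them only; others in the source may bear on it.

Of the compounds shown here, three built on one shared core have so far been measured in a functional assay on PC-12 cells (Rattus norvegicus) for cytotoxicity, read by MTT assay, with stated times of 3 h and 2 h, tested at 5 uM; a lower number here means a weaker effect, a higher number a stronger effect of the compound at the concentration tested. Compound 1 `Cc1cc(=O)oc2cc(OCCCn3cc(CNC(=O)CCCCC4CCSS4)nn3)ccc12` gives 64.6%. Compound 2 `CCOC(=O)c1cc2ccc(OCCCn3cc(CNC(=O)CCCCC4CCSS4)nn3)cc2oc1=O` gives 32.4%. Compound 3 `CC(=O)c1cc2ccc(OCCCCCn3cc(CNC(=O)CCCCC4CCSS4)nn3)cc2oc1=O` gives 22.2%, the lowest of the three numbers: compound 2 lies above it by a margin beyond the scatter, and compound 1 lies further above it, also beyond the scatter. Compound 4 `O=C(CCCCC1CCSS1)NCc1cn(CCCCCOc2ccc3cc(-c4ccc(Br)cc4)c(=O)oc3c2)nn1` has not yet been measured. It differs from compound 3 in a single place: 4-bromophenyl in place of acetyl on an aromatic carbon. Among the compounds with values here, no measured pair isolates this change, so the expectation rests on the spread of the three numbers alone. The step of a number 7.8 percentage points higher from compound 3 to compound 4 (within the scatter) is expected to be small and upward, probably within the scatter. Compound 4 is estimated at 30%, within a range from 12% to 55%.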

Compound 4, a percentage reported as activity, at one concentration (the size of the read-out at that concentration, not a potency): 45.7%
Compound 4: the middle estimate sits 15.7 percentage points below what was measured, and the stated range covers the measured number.
By their numbers in this assay, from the lowest: compound 3; then compound 2; then compound 4; then compound 1.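

In this assay, the group on this aromatic carbon, two atoms from the ring oxygen, can by itself shift the read-out: 4-bromophenyl in place of acetyl gives a number 23.5 percentage points higher from compound 3 to compound 4 (beyond the scatter). Within the data shown here, this is the only pair so far that differs in one place, so the earlier compounds could not separate this position from the other differences among them. No measurement available here bears on the reason for the rise.

The compounds shown leave open whether the step belongs to the aromatic ring or to the bromine, which plain phenyl would separate. They also leave open whether an amine on this carbon would move the number in the same direction.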